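From compound 3 to compound 4: one group exchanged

The compounds below may be only part of what the source reports. "The series", "measured", "known", "first", "only" and "open" are said of these compounds alone.

Values measured in an ADME assay (liver) for metabolic stability, with Liver microsome (Homo sapiens) as the target, using microsomes and NADPH, with a stated time of 30 min, tested at 1 uM (a lower number here means slower removal, a higher number faster removal of the compound), are these
- Compound 1 `Nc1ccc(S(=O)(=O)N2CCN(c3ncc(C(O)(C(F)(F)F)C(F)(F)F)cc3C3CC3)CC2)cn1` gives 38 mL.min-1.g-1
- Compound 2 `Nc1ccc(S(=O)(=O)N2CCN(c3ncc(C(O)(C(F)(F)F)C(F)(F)F)cc3C#CC3CC3)CC2)cn1` gives < 14 mL.min-1.g-1 (a limit of the assay, not a number)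
- Compound 3 `CCn1cc(-c2cc(C(O)(C(F)(F)F)C(F)(F)F)cnc2N2CCN(S(=O)(=O)c3ccc(N)nc3)CC2)cn1` gives 20 mL.min-1.g-1

Only compound 1 offers an exact number to set against compound 3, and that comparison is a 1.9-fold lower number from compound 1 to compound 3 (0.28 log units; within the scatter).

Compound 4 `Cc1csc(-c2cc(C(O)(C(F)(F)F)C(F)(F)F)cnc2N2CCN(S(=O)(=O)c3ccc(N)nc3)CC2)c1` differs from compound 3 at one place (4-methylthiophen-2-yl in place of 1-ethyl-1H-pyrazol-4-yl on an aromatic carbon), where 4-methylthiophen-2-yl enters in place of 1-ethyl-1H-pyrazol-4-yl on an aromatic carbon. Within the data shown here, no measured step covers this exact exchange, but other exchanges at the same place bear on it. Besides the comparison above, they are an at least 2.7-fold lower number from compound 1 to compound 2 (0.43 log units; beyond the scatter) and an at least 1.4-fold higher number from compound 2 to compound 3 (0.15 log units; that floor lies within the scatter). Of these three, only the first of the two just given lies beyond the scatter, and it is modest in size. A large change is therefore not expected here, and the lean towards a higher number is only a cautious one. The expected step is a 1.5-fold higher number from compound 3 to compound 4 (0.18 log units; within the scatter), which would not clearly exceed the scatter. For compound 4 the estimated value is 30 mL.min-1.g-1, with an expected range from 14 mL.min-1.g-1 to 65 mL.min-1.g-1.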

Compound 4, intrinsic clearance in microsomes: 29 mL.min-1.g-1
Compound 4: the middle estimate sits 1.0-fold (0.01 log units) above what was measured; the range from low to high includes it.
By their numbers in this assay, from the lowest: compounds 3, 4 and 1 (each within the scatter of the next). At a limit, below all of these: compound 2.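

In this assay, exchanging one five-membered aromatic ring for another at this carbon gives a 1.5-fold higher number from compound 3 to compound 4 (0.16 log units; within the scatter) and so does not separate 4-methylthiophen-2-yl, with its one hetero atom, from 1-ethyl-1H-pyrazol-4-yl, with two, while a 1.3-fold lower number from compound 1 to compound 4 (0.12 log units; within the scatter) likewise leaves it unseparated from cyclopropyl. Of the groups shown at this position, only 2-cyclopropylethynyl stands clearly apart from 4-methylthiophen-2-yl, with an at least 2.0-fold higher number from compound 2 to compound 4 (0.31 log units; beyond the scatter) as the step. Compound 2 carries a limit of the assay and not a number: the limit of < 14 mL.min-1.g-1 in this assay, at which 1 of the 4 values shown sits.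

Going by these compounds, how far an aminomethyl group or a carboxylic acid on this aromatic carbon would move the number remains open. Also open, on these data alone, is what the methyl group of 4-methylthiophen-2-yl contributes, a question that a plain thiophen-2-yl group would answer.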